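The source may report more compounds than this note shows. Statements on the series, on what has been measured and on what is new or still open speak of the compounds shown alone.

Compound 3 `CC1=C(C(=O)NC(C)C)C(c2ccsc2)NC(=O)N1` carries an isopropylamide on the shared core. In an assay on membranes from HeLa cells for displacement of a labelled ligand from adenosine receptor A3 (Homo sapiens), read by scintillation counting, with a stated time of 180 min, tested at 1 uM (a higher number here means more inhibition at the concentration tested (going by the name of the read-out), a lower number less inhibition), compound 3 gives 1%. Its two neighbours differ from it only in the five-membered aromatic ring attached to the saturated ring carbon: compound 1 `CC1=C(C(=O)NC(C)C)C(c2ccco2)NC(=O)N1` gives 4%, and compound 2 `CC1=C(C(=O)NC(C)C)C(c2cccs2)NC(=O)N1` gives 1%. The step of a number 3 percentage points lower from compound 1 to compound 3 (within the scatter) and the step of no change at the digits printed from compound 2 to compound 3 (within the scatter) both stay within the scatter, as does a number 3 percentage points lower from compound 1 to compound 2 (within the scatter). Compound 3 thus sits level with compound 2 at the digits shown, the two together being the lowest of the three numbers, while compound 1 cannot be told apart from them either.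

Compound 4 `CCC(C)OC(=O)C1=C(C)NC(=O)NC1c1ccsc1` keeps the thiophen-3-yl of compound 3 and changes the other side of the core: sec-butoxy in place of isopropylamino on a carbonyl carbon. Among the compounds with values here, none of the measured steps touches this carbonyl carbon; all three exchange only the aromatic ring, and all three lie within the scatter. Within the data shown here, the numbers therefore give no pointer to a change beyond the scatter in this assay in either direction, and the only guide is that every measured compound shows very little inhibition. Compound 4 is expected to show a number 2 percentage points higher from compound 3 to compound 4 (within the scatter). The estimate for compound 4 is 3%, expected to fall between -8% and 16%.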

Compound 4, a percentage reported as inhibition, at one concentration (the size of the read-out at that concentration, not a potency): 7%
For compound 4 the middle estimate is 4 percentage points below the measured one, within the range that was stated.
By their numbers in this assay, from the lowest: compounds 2, 3, 1 and 4 (each within the scatter of the next).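

Within the data shown here, compound 4 gives the first reading at the carbonyl carbon, since the earlier steps exchanged only the aromatic ring. In this assay, putting sec-butoxy in place of isopropylamino gives a number 6 percentage points higher from compound 3 to compound 4 (within the scatter), so this exchange, which takes away the hydrogen-bond donor of isopropylamino and brings in the hydrogen-bond acceptor of sec-butoxy, cannot be told apart from no effect at the concentration tested. Nothing measured here explains the reading for this pair, and no cause can be assigned to it.

Still open, going by these compounds, is whether any other group on this carbonyl carbon, such as a free carboxylic acid, a benzylamine or a longer alkoxy chain, would produce a step beyond the scatter in this assay. Also open is whether sec-butoxy would read the same with furan-2-yl or thiophen-2-yl on the saturated ring carbon, as the compounds shown pair it only with thiophen-3-yl.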